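The source may hold more compounds than are shown below. What is called first, only, known or untested is meant among the compounds shown, and "the series" means these compounds.

Measured so far in a functional assay on U-87MG ATCC cells (Homo sapiens) for inhibition; a lower number here means a stronger inhibitor, a higher number a weaker inhibitor:
- compound 1 `COc1cc(/C=C/C(=O)c2cccc(NC(=O)c3cccs3)c2)ccc1O` gives 14.7 ug/mL
- compound 2 `COc1cc(/C=C/C(=O)c2cccc(N)c2)ccc1O` gives 7.71 ug/mL

For the measured compounds named here, compound 2 has the lower of only two numbers, but the gap is within the scatter, so no ranking can be drawn from it. Compound 3 `COc1cc(/C=C/C(=O)c2cccc(NC(=O)c3ccc(Cl)c(Cl)c3)c2)ccc1O` is still unmeasured. It has (3,4-dichlorophenyl)carbonyl in place of hydrogen on a nitrogen on an aromatic ring. Going by the values given here, one measured step bears on this change, and it exchanges the same nitrogen's hydrogen with a different carbonyl group, (thiophen-2-yl)carbonyl, in compound 1: a 1.9-fold lower number from compound 1 to compound 2 (0.28 log units; within the scatter). Adding a carbonyl group at this nitrogen is therefore expected to produce no step beyond the scatter in this assay, with a slightly higher number the likelier direction. The expected step is a 1.6-fold higher number from compound 2 to compound 3 (0.19 log units; within the scatter). A single step is thin support, so the range is kept wide. The estimate for compound 3 is 12 ug/mL, within an expected range of 5 ug/mL to 28 ug/mL.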

Compound 3, half-maximal inhibitory concentration: 29.5 ug/mL
Estimate against measurement, compound 3: 2.5-fold (0.39 log units) below; the whole stated range lies below it.
By their numbers in this assay, from the lowest: compounds 2, 1 and 3 (each within the scatter of the next, the first and the last beyond it).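

For the compounds shown here, on the nitrogen on an aromatic ring, (3,4-dichlorophenyl)carbonyl in place of hydrogen gives a 3.8-fold higher number from compound 2 to compound 3 (0.58 log units; beyond the scatter) in this assay, the only step at this position that passes the scatter, so a carbonyl group here can measurably weaken inhibition. The ring on the carbonyl carbon does not separate the two amides: 3,4-dichlorophenyl in place of thiophen-2-yl gives a 2.0-fold higher number from compound 1 to compound 3 (0.30 log units; within the scatter), and these two cannot be told apart. Nothing measured here bears on why the step on this nitrogen occurs.

Open, from the compounds shown here alone, is whether a small acetyl group, with no ring on the carbonyl carbon, or a simple methyl group on this nitrogen stays close to the free amine. Also open, going by these compounds, is what the two chlorine atoms contribute, which a plain benzoyl group on the same nitrogen would show.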